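A few compounds are considered here, and "the series" means these few. Any claim that something is new, unique, unknown or untested is made for them only; others in the source may bear on it.

Measured so far:
- compound 1 `CCN1CCN(c2nc(C)cc(NCCCCNc3ccnc4cc(Cl)ccc34)n2)CC1`: 10700 nM
- compound 2 `Cc1cc(Cl)nc(NCCCCCCNc2ccnc3cc(Cl)ccc23)n1`: 24000 nM

In an ADME assay on LLC-PK11 cells (Sus scrofa) for cytotoxicity, read by neutral red uptake, with a stated time of 48 h (on this read-out lower numbers stand for stronger inhibition and higher numbers for weaker inhibition), compound 1 gives 10700 nM, the lower of the two numbers. Compound 2 gives 24000 nM, and its gap to compound 1 lies beyond the usual scatter. These two compounds do not differ in one place only, so they show nothing about a single change.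

Compound 3 `Cc1cc(NCCCCNc2ccnc3cc(Cl)ccc23)nc(N2CCN(C)CC2)n1` has not yet been measured. Its change from compound 1 is hydrogen in place of methyl on a saturated chain carbon bound to an amine nitrogen in a ring, which also reads as 4-ethylpiperazin-1-yl to 4-methylpiperazin-1-yl. Going by the values given here, no measured pair shows this change, so the expectation rests on compound 1 at 10700 nM, with no step beyond the scatter expected in this assay in either direction. The expected step is a 1.1-fold higher number from compound 1 to compound 3 (0.05 log units; within the scatter). For compound 3 the estimated value is 12000 nM, with an expected range of 5000 nM to 28000 nM.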

Compound 3, half-maximal inhibitory concentration: 34600 nM
For compound 3 the middle estimate is 2.9-fold (0.46 log units) below the measured one; the measured number lies above the stated range.
By their numbers in this assay, from the lowest: compound 1; then compounds 2 and 3 (each within the scatter of the next).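

In this assay, going by these compounds alone, hydrogen in place of methyl on a saturated chain carbon bound to an amine nitrogen in a ring gives a 3.2-fold higher number from compound 1 to compound 3 (0.51 log units; beyond the scatter), the first comparison that isolates a single change. It shows that this position is not silent: trimming 4-ethylpiperazin-1-yl to 4-methylpiperazin-1-yl moves the number towards weaker inhibition, though this rests on one pair on one core. No measurement at hand bears on the reason for this step.

Open, as far as these compounds go, is whether a longer chain such as propyl, or a 2-hydroxyethyl group, in place of the ethyl would take the number lower or higher than in compound 1. Compound 2 carries neither piperazine group, so it does not show whether the same change gives a similar step on another core.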